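Lengthening the Ester Chain: Half-Life Expected to Stay Put

The source may hold more compounds than are shown below. What is called first, only, known or untested is meant among the compounds shown, and "the series" means these compounds.

Measured so far:
compound 1, `CCOC(=O)[C@@H](N)CCC(=O)NCCSC(=O)c1ccccc1`: 0.167 h
compound 2, `CCCCOC(=O)[C@@H](N)CCC(=O)NCCSC(=O)c1ccccc1`: 0.167 h
compound 3, `CCOC(=O)[C@@H](N)CCC(=O)NCCSC(=O)C(C)(C)C`: 0.167 h

In an ADME assay on isolated protein for metabolic stability, with Cocaine esterase (Homo sapiens) as the target (a lower number here means that the compound disappears faster, a higher number that the compound lasts longer), compound 1 gives 0.167 h. Compound 1 stands level with compound 2 and compound 3, the step of no change at the digits printed from compound 1 to compound 2 (within the scatter) and the step of no change at the digits printed from compound 1 to compound 3 (within the scatter) both lying within the scatter.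

Compound 4, `CCCOC(=O)[C@@H](N)CCC(=O)NCCSC(=O)c1ccccc1`, differs from compound 1 by methyl in place of hydrogen on a saturated chain carbon, two bonds along the chain from an oxygen next to a carbonyl group. The step from compound 1 to compound 2 alters the same chain carbon with a larger group and left this assay unchanged, and the change elsewhere in compound 3 did likewise. The expected step for compound 4 is therefore none beyond the scatter, no change at the digits printed from compound 1 to compound 4 (within the scatter). Compound 4 is estimated at 0.167 h, with an expected range from 0.09 h to 0.33 h.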

Compound 4, half-life: 0.167 h
Compound 4: middle estimate and measured number agree at the digits printed; the measured number falls inside the stated range.
By their numbers in this assay, from the lowest: compounds 1, 2, 3 and 4 (each within the scatter of the next).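

Adding methyl at this saturated chain carbon in this assay gives no change at the digits printed from compound 1 to compound 4 (within the scatter) and taking methyl away one carbon further out gives no change at the digits printed from compound 2 to compound 4 (within the scatter) so the half-life now reads level across three ester chain lengths. The middle length fills the gap between the two earlier chains and shows no hidden rise or dip at this step. Still open, as far as these compounds go, is whether a branched chain, an amine or a carboxylic acid at this carbon would shift the half-life. No measured evidence accounts for this level result.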